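Swapping the Pendant Aryl Group: Effect on Microsomal Half-Life

This account rests on a few compounds, and the source may have more. Where it says the series, first, only, none or still open, it means among the compounds named here.

Measured compounds:
compound 1 `COc1ccc(C2=Nc3c(C(C)(C)C)nn(CCCO)c3C(=O)NC2)cc1-c1ccc(C(=O)O)cc1`: 2 h
compound 2 `COc1ccc(-c2cc(C3=Nc4c(C(C)(C)C)nn(CCCO)c4C(=O)NC3)ccc2OC)cn1`: 2 h

In an ADME assay on microsomes from liver (Homo sapiens) for metabolic stability (on this read-out lower numbers stand for a shorter-lived compound and higher numbers for a longer-lived compound), compound 2 stands level with compound 1 at the digits shown. Among the compounds with values here, the single measured step, no change at the digits printed from compound 1 to compound 2 (within the scatter), lies within the scatter, so exchanging the group on the aromatic carbon has so far left the half-life unmoved.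

Compound 3 `COc1ccc(C2=Nc3c(C(C)(C)C)nn(CCCO)c3C(=O)NC2)cc1-c1cnn(C)c1` has not been measured. Its difference from compound 2 is 1-methyl-1H-pyrazol-4-yl in place of 6-methoxypyridin-3-yl on an aromatic carbon. Within the data shown here, the change sits at the same aromatic carbon as the one measured step, and that step was flat. Among the measured compounds shown here, with only this one step to go on, the expectation for compound 3 is no shift beyond the scatter in this assay. For compound 3 the expected step is no change at the digits printed from compound 2 to compound 3 (within the scatter). Compound 3 is therefore estimated at 2 h, with a range from 1 h to 4 h.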

Compound 3, half-life: 2 h
Estimate against measurement, compound 3: no gap at the digits printed, within the range that was stated.
By their numbers in this assay, from the lowest: compounds 1, 2 and 3 (each within the scatter of the next).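

In this assay, a five-membered ring can take the place of a six-membered one on this aromatic carbon, ortho to a methoxy group: exchanging 6-methoxypyridin-3-yl for 1-methyl-1H-pyrazol-4-yl gives no change at the digits printed from compound 2 to compound 3 (within the scatter). Exchanging 4-carboxyphenyl for 1-methyl-1H-pyrazol-4-yl likewise gives no change at the digits printed from compound 1 to compound 3 (within the scatter), so all three aromatic groups shown, with either ring size and with or without a carboxylic acid, sit level on this read-out. Nothing available explains why the half-life holds steady across these changes.

Going by these compounds, whether a non-aromatic group on this carbon, such as an amine or a short alkyl chain, would shift the half-life remains open. Every step shown also sits at this one carbon, so the effect of changes elsewhere on the shared core is equally unknown.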